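A few compounds are considered here, and "the series" means these few. Any claim that something is new, unique, unknown or untested is made for them only; others in the source may bear on it.

In a functional assay on KB cells (Homo sapiens) for inhibition (a lower number here means a stronger inhibitor, a higher number a weaker inhibitor), compound 1 `Cc1ccc(Cn2c(N)nc3cc(Cl)c(Cl)cc32)cc1` gives 50000 nM and compound 3 `COc1ccc(Cn2c(Br)nc3cc(Cl)c(Cl)cc32)cc1` gives 55000 nM, two values within the scatter of each other. Compound 2 `Clc1cc2nc(Br)n(Cc3ccccc3)c2cc1Cl` gives > 100000 nM, which is a limit of the assay and not a number. Compound 4 `Cc1ccc(Cn2c(Br)nc3cc(Cl)c(Cl)cc32)cc1` has methyl in place of methoxy on an aromatic carbon, para to a large group: methyl in place of methoxy on an aromatic carbon. Going by the values given here, one measured step bears on this place: methoxy in place of hydrogen on an aromatic carbon gives an at least 1.8-fold lower number from compound 2 to compound 3 (0.25 log units; that floor lies within the scatter). It offers no firm size to carry over, so no change beyond the scatter is expected in this assay. The expected step is a 1.1-fold higher number from compound 3 to compound 4 (0.04 log units; within the scatter). Compound 4 is expected at 60000 nM, with an estimated range of 30000 nM to 100000 nM.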

Compound 4, half-maximal inhibitory concentration: > 100000 nM
Compound 4: no number, only a limit; the forecaster's own chance of this, stated with the estimate: 25%; middle value at least 1.6-fold (0.22 log units) away from the limit.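

In this assay compound 4 gives > 100000 nM, a limit and not a number. Methyl in place of methoxy on this aromatic carbon gives an at least 1.8-fold higher number from compound 3 to compound 4 (0.25 log units; that floor lies within the scatter), and bromo in place of amino gives an at least 2.0-fold higher number from compound 1 to compound 4 (0.30 log units; that floor lies within the scatter), so among the bromo compounds only compound 3, with methoxy, now reads as a number, though neither floor clears the scatter. The step from compound 2 to compound 4 cannot be read, as both stop at the same limit: the limit of > 100000 nM in this assay, at which 2 of the 4 values shown sit.

As far as these compounds go, how far compound 4 lies past that limit stays open. Also open, from the compounds shown here alone, is how an ethoxy group or a carboxylic acid on this aromatic carbon would read with the bromo compounds.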